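The source may hold more compounds than are shown below. What is called first, only, known or untested is meant among the compounds shown, and "the series" means these compounds.

Of the compounds shown here, three of one series have been tested in a functional assay on the whole organism (strain Swiss) with Mus musculus as the target, in the maximal electroshock model, with a stated time of 1 h, at a dose of 300 mg/kg by the intraperitoneal route; on this read-out higher numbers stand for a stronger effect at the one dose given and lower numbers for a weaker effect. Compound 1 `CC(C(=O)N1CCN(c2ccc(C(F)(F)F)cc2)CC1)N1C(=O)CCC1=O` gives 0%, compound 2 `CCC(C(=O)N1CCN(c2ccc(C(F)(F)F)cc2)CC1)N1C(=O)CCC1=O` gives 0%, and compound 3 `CCC(C(=O)N1CCN(c2ccc(F)cc2)CC1)N1C(=O)CCC1=O` gives 25%. The change hydrogen in place of methyl on a saturated chain carbon, two bonds along the chain from an amide-type nitrogen in a ring and a carbonyl carbon made no change at the digits printed from compound 2 to compound 1 (within the scatter). The change between the two cores, (fluoro in place of trifluoromethyl on an aromatic carbon), made a number 25 percentage points higher from compound 2 to compound 3 (beyond the scatter). Compound 4 `CC(C(=O)N1CCN(c2ccc(F)cc2)CC1)N1C(=O)CCC1=O` has not yet been measured in this assay; it carries the change (hydrogen in place of methyl on a saturated chain carbon, two bonds along the chain from an amide-type nitrogen in a ring and a carbonyl carbon), the same change as that from compound 2 to compound 1, but placed on the core of compound 3 rather than on the core of compound 2. Since that change gave no change at the digits printed from compound 2 to compound 1 (within the scatter), the step from compound 3 to compound 4 is expected to be a number 3 percentage points lower from compound 3 to compound 4 (within the scatter), though this rests on one pair only. For compound 4 the value in this assay is estimated at 22%, within 0% to 45%.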

Compound 4, a percentage reported as activity, at one dose (the size of the read-out at that dose, not a potency): 25%
For compound 4 the middle estimate is 3 percentage points below the measured one; measured number inside the range.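

In this assay, the change from ethyl to methyl on the core of compound 3 gave no change at the digits printed from compound 3 to compound 4 (within the scatter), matching the same change on the other core: the same change on two cores in this assay, no change at the digits printed (within the scatter) from compound 2 to compound 1 and no change at the digits printed (within the scatter) from compound 3 to compound 4, 0 percentage points apart, within the scatter of two such steps. Fluoro in place of trifluoromethyl gave a number 25 percentage points higher from compound 1 to compound 4 (beyond the scatter), which also matched its earlier step: the same change on two cores in this assay, a number 25 percentage points higher (beyond the scatter) from compound 2 to compound 3 and a number 25 percentage points higher (beyond the scatter) from compound 1 to compound 4, 0 percentage points apart, within the scatter of two such steps. Going by these compounds alone, both changes thus carried from one core to the other in these four compounds, but each comparison rests on only two steps at a single dose and shows nothing about any other core.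

The compounds shown leave open what a longer chain would do on the saturated chain carbon. They also leave open how a chloro or methoxy group would compare with fluoro on the aromatic carbon.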